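The compounds below may be only part of what the source reports. "The series", "measured", "known", "first", "only" and "open" are said of these compounds alone.

Two compounds of this series have been run in an in vitro functional assay on HEK285-7 cells for antagonist activity at prostaglandin D2 receptor 2 (Homo sapiens), read by BRET and beta-arrestin recruitment (a lower number here means a stronger inhibitor, a higher number a weaker inhibitor), so far. Compound 1 `O=C(O)Cc1sc(C(c2ccccc2)c2ccccc2)nc1-c1ccccc1` gives 370 nM and stands as the highest of the two numbers. Compound 2 `O=C(O)Cc1sc(C(c2ccc(F)cc2)c2ccc(F)cc2)nc1-c1ccccc1`, which differs in both of its phenyl rings on the diphenylmethyl group, gives 240 nM; the two values lie within the scatter of each other, so no difference between them can be claimed.

Compound 3 `O=C(O)Cc1sc(C(c2ccccc2)c2ccccc2)nc1-c1ccc(F)cc1` differs from compound 1 by fluoro in place of hydrogen on an aromatic carbon. Among the measured compounds shown here, no step of this kind has yet been measured. For the measured compounds named here, nothing among the measured pair suggests more than a small effect, and the expectation is for no step beyond the scatter. Compound 3 is accordingly estimated at 300 nM, with a range from 120 nM to 750 nM, which corresponds to an expected 1.2-fold lower number from compound 1 to compound 3 (0.09 log units; within the scatter).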

Compound 3, half-maximal inhibitory concentration: 77 nM
Beside the measured number, compound 3's estimate is 3.9-fold (0.59 log units) above it; the measured number lies below the stated range.
By their numbers in this assay, from the lowest: compound 3; then compounds 2 and 1 (each within the scatter of the next).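

In this assay, among the compounds shown here, the change from phenyl to 4-fluorophenyl on the ring outside the diphenylmethyl group gives a 4.8-fold lower number from compound 1 to compound 3 (0.68 log units; beyond the scatter) as the first step beyond the scatter. This position therefore responds to a single fluoro in place of hydrogen. No available measurement accounts for the step.

On these data alone, whether chloro, methoxy or an amine in the same place would give a step of similar size remains open. Also open, as far as these compounds go, is how this fluoro would combine with the two fluoro groups of compound 2.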